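Methoxy to Chloro on a Cytotoxic Thiazolidinone Pair

A few compounds are considered here, and "the series" means these few. Any claim that something is new, unique, unknown or untested is made for them only; others in the source may bear on it.

Compound 1 `COc1ccc(-c2cc(/N=C3/NC(=O)CS3)cs2)cc1` and compound 2 `O=C1CS/C(=N\c2csc(-c3ccc(Cl)cc3)c2)N1` differ only in chloro in place of methoxy on an aromatic carbon. In a functional assay on SW-620 cells (Homo sapiens) for cytotoxicity, read by MTT assay, with a stated time of 72 h (a higher number here means a weaker inhibitor, a lower number a stronger inhibitor), compound 1 returns a limit, > 50000 nM. Compound 2 likewise returns a limit in this assay, > 50000 nM. The step that the two limits leave unreadable from compound 1 to compound 2 therefore carries no readable size, because both values sit at the limit of > 50000 nM in this assay, at which 2 of the 3 values shown sit. For the measured compounds named here, compound 3 `COc1ccc(-c2cc(/N=C3\SCC(=O)N3c3cccc(OC)c3)cs2)cc1` differs from compound 1 by 3-methoxyphenyl in place of hydrogen on an amide-type nitrogen in a ring; in this assay compound 3 gives 3500 nM, the only genuine number among the three, and the step of an at least 14-fold lower number from compound 1 to compound 3 (1.15 log units; beyond the scatter) is the one clear movement in the set. Compound 4 `COc1cccc(N2C(=O)CS/C2=N\c2csc(-c3ccc(Cl)cc3)c2)c1` repeats the same change on compound 3, namely (chloro in place of methoxy on an aromatic carbon), with the same surroundings as before. Since the earlier instance of this change left no measurable size, the expected step of a 1.1-fold higher number from compound 3 to compound 4 (0.06 log units; within the scatter) is small, with compound 4 remaining near compound 3. Compound 4 is accordingly estimated at 4000 nM in this assay, within a range from 1500 nM to 12000 nM, on the strength of the value of compound 3, 3500 nM.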

Compound 4, half-maximal inhibitory concentration: 33000 nM
Beside the measured number, compound 4's estimate is 8.3-fold (0.92 log units) below it; the measured number lies above the stated range.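

In this assay, chloro in place of methoxy on the core bearing the 3-methoxyphenyl group gives a 9.4-fold higher number from compound 3 to compound 4 (0.97 log units; beyond the scatter), whereas the same change on the core of compound 1 cannot be read, because both of its values are limits: the limit of > 50000 nM in this assay, at which 2 of the 4 values shown sit. Seen from the other side, 3-methoxyphenyl in place of hydrogen on the amide-type nitrogen gives an at least 1.5-fold lower number from compound 2 to compound 4 (0.18 log units; that floor lies within the scatter), a floor only, which stands against the earlier step on the other core: the same change on two cores in this assay, an at least 14-fold lower number (1.15 log units; beyond the scatter) from compound 1 to compound 3 and an at least 1.5-fold lower number (0.18 log units; that floor lies within the scatter) from compound 2 to compound 4; the limit leaves it open whether they differ. The four compounds thus show a readable chloro step on one core, but they do not show whether that step has a like size on the core of compound 1, or whether the 3-methoxyphenyl step carries over from one core to the other.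

On these data alone, it remains open how the 4-methoxyphenyl to 4-chlorophenyl change behaves with a methyl or benzyl group on the amide-type nitrogen. As far as these compounds go, it is also open how a fluoro or dimethylamino group would read in the place of methoxy.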